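Fluoro added to the bromophenyl ring of compound 3

The source may hold more compounds than are shown below. What is called first, only, known or untested is meant among the compounds shown, and "the series" means these compounds.

The series shares one core, seen in compound 1 `O=C(Nc1ccc(Oc2ccnc3[nH]ccc23)cc1)c1nn(-c2ccc(Br)cc2F)ccc1=O`, compound 2 `O=C(Nc1ccc(Oc2ccnc3[nH]ccc23)c(F)c1)c1nn(-c2ccc(Cl)cc2)ccc1=O` and compound 3 `O=C(Nc1ccc(Oc2ccnc3[nH]ccc23)c(F)c1)c1nn(-c2ccc(Br)cc2)ccc1=O`. In a functional assay on PC-3 cells (Homo sapiens) for cytotoxicity, read by MTT assay, with a stated time of 72 h (a higher number here means a weaker inhibitor, a lower number a stronger inhibitor), compound 1 gives 12800 nM, compound 2 gives 42500 nM and compound 3 gives 40800 nM. Compound 3 thus stands second highest of the three numbers; its nearest neighbour is compound 2, with a 1.0-fold lower number from compound 2 to compound 3 (0.02 log units; within the scatter), and the furthest is compound 1, whose number is lower beyond the scatter. Compound 1 and compound 3 differ in two places, so their gap cannot be assigned to either change.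

Compound 4 `O=C(Nc1ccc(Oc2ccnc3[nH]ccc23)c(F)c1)c1nn(-c2ccc(Br)cc2F)ccc1=O` is compound 3 with fluoro in place of hydrogen on an aromatic carbon, placed ortho to a large group and meta to a bromo group. Going by the values given here, no measured pair isolates this change; the only single-point step, bromo in place of chloro, stayed within the scatter. Among the compounds with values here, the lower number of compound 1, which also carries a 4-bromo-2-fluorophenyl, is the sole hint that the number might fall, but it is confounded by the second difference.

For compound 4 a modest step, a 1.6-fold lower number from compound 3 to compound 4 (0.21 log units; within the scatter), is therefore expected in this assay, with wide uncertainty. Compound 4 is estimated at 25000 nM, within a range of 9000 nM to 60000 nM.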

Compound 4, half-maximal inhibitory concentration: 8800 nM
Compound 4: the middle estimate sits 2.8-fold (0.45 log units) above what was measured; the measured number lies below the stated range.
By their numbers in this assay, from the lowest: compounds 4 and 1 (each within the scatter of the next); then compounds 3 and 2 (each within the scatter of the next).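

In (this assay), the change from 4-bromophenyl to 4-bromo-2-fluorophenyl moves the number beyond the scatter (a 4.6-fold lower number from compound 3 to compound 4 (0.67 log units; beyond the scatter)), so this ring position responds to a single added fluoro in a way the bromo and chloro exchange (a 1.0-fold lower number from compound 2 to compound 3 (0.02 log units; within the scatter)) did not show. The same ring also stands beyond the scatter against 4-chlorophenyl (a 4.8-fold lower number from compound 2 to compound 4 (0.68 log units; beyond the scatter)), whereas fluoro in place of hydrogen on the other aromatic carbon stays within it when the 4-bromo-2-fluorophenyl is already present (a 1.5-fold lower number from compound 1 to compound 4 (0.16 log units; within the scatter)), so the two fluoro changes do not read alike here. Nothing available gives a measured reason for the step at this position.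

The compounds shown leave open whether the step depends on the bromo group, since 4-chloro-2-fluorophenyl does not appear among them, and whether the step is particular to fluoro or would also follow from a methyl, methoxy or amine group at the same position. They also do not show whether the step seen with the fluoro-bearing core would carry over to the core of compound 1, which lacks that second fluoro and has no 4-bromophenyl partner here.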